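Moving the thiazole attachment on the shared core

This account rests on a few compounds, and the source may have more. Where it says the series, first, only, none or still open, it means among the compounds named here.

Measured in a functional assay (trachea) with Cavia porcellus as the target; a higher number here means a weaker inhibitor, a lower number a stronger inhibitor:
compound 1 `Oc1nnc(-n2cncn2)c2ccccc12` 16600 nM
compound 2 `Oc1nnc(-c2nccs2)c2ccccc12` 4570 nM

Among the measured compounds shown here, of these two, compound 2 at 4570 nM holds the lower number, and compound 1 is its only neighbour. Compound 3 (`Oc1nnc(-c2cncs2)c2ccccc12`) keeps the shared core and changes only the ring attachment: 1,3-thiazol-5-yl in place of 1,3-thiazol-2-yl on an aromatic carbon. For the measured compounds named here, no measured step covers this exact change. Going by the values given here, the one step available, a 3.6-fold lower number from compound 1 to compound 2 (0.56 log units; beyond the scatter), exchanged one five-membered aromatic ring for another on an aromatic carbon and was modest, though beyond the scatter. With the same atoms kept in compound 3 and only their joining altered, a step no larger than that one is expected in this assay. Among the compounds with values here, the two measured compounds do not fix a direction, but a small rise is the slightly likelier outcome, since only one other number is available and it lies higher. For compound 3 the estimated value is 6000 nM, with an expected range of 1800 nM to 18000 nM. The estimated change is a 1.3-fold higher number from compound 2 to compound 3 (0.12 log units; within the scatter).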

Compound 3, half-maximal inhibitory concentration: 1200 nM
Compound 3: the middle estimate sits 5.0-fold (0.70 log units) above what was measured; the whole stated range lies above it.
By their numbers in this assay, from the lowest: compound 3; then compound 2; then compound 1.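

In this assay, among the compounds shown here, the way the thiazole is joined to the shared core matters on its own: with the same atoms and the same counts of donors and acceptors, moving from 1,3-thiazol-2-yl to 1,3-thiazol-5-yl gives a 3.8-fold lower number from compound 2 to compound 3 (0.58 log units; beyond the scatter) and so exchanging one ring for another is not the only change at this aromatic carbon that shifts the number. Replacing 1H-1,2,4-triazol-1-yl with 1,3-thiazol-5-yl gives a 14-fold lower number from compound 1 to compound 3 (1.14 log units; beyond the scatter) and is the largest step in the set, and compound 3 now holds the lowest number, with its steps to both other compounds beyond the scatter. Nothing available explains why the two thiazole attachments differ.

Still open, from the compounds shown here alone, is where 1,3-thiazol-4-yl would fall in this order, and whether a methyl group or an amine on the 1,3-thiazol-5-yl ring would lower the number further or raise it. Going by these compounds, the role of the hydroxy group, constant across all three compounds, is also open, as is whether a methoxy group or an amine could stand in its place.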